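Cyclopentyl in place of cyclohexyl on the ether chain

The source may report more compounds than this note shows. Statements on the series, on what has been measured and on what is new or still open speak of the compounds shown alone.

Measured so far in a functional assay on PC-3 cells (Homo sapiens) for antiproliferative activity, read by sulforhodamine B assay; on this read-out higher numbers stand for weaker inhibition of growth and lower numbers for stronger inhibition of growth (three compounds):
compound 1 `CCCCCCOc1cccc(O)c1C(=O)/C=C/c1ccc(O)cc1` gives > 30000 nM (a limit)
compound 2 `CC(C)(C)CCOc1cccc(O)c1C(=O)/C=C/c1ccc(O)cc1` gives 3220 nM
compound 3 `O=C(/C=C/c1ccc(O)cc1)c1c(O)cccc1OCC1CCCCC1` gives > 30000 nM (a limit)

Compound 3 has no number and sits at the limit of > 30000 nM in this assay, at which 2 of the 3 values shown sit. The change to compound 4 `O=C(/C=C/c1ccc(O)cc1)c1c(O)cccc1OCC1CCCC1` is cyclopentyl in place of cyclohexyl on a saturated chain carbon bound to an oxygen on an aromatic ring, cyclopentyl in place of cyclohexyl. The nearest evidence is an at least 9.3-fold higher number from compound 2 to compound 3 (0.96 log units; beyond the scatter), and an at least 9.3-fold lower number from compound 1 to compound 2 (0.96 log units; beyond the scatter) shows the same chain place moving the read-out. The third step, a step that the two limits leave unreadable from compound 1 to compound 3, says nothing on size. For the measured compounds named here, no measured step changes ring size. A modest shift towards a lower number is expected at most, with a limit result still likely. The expected step is an at least 1.2-fold lower number from compound 3 to compound 4 (0.07 log units; that floor lies within the scatter) in this assay. Compound 4 is estimated at 25000 nM, with an expected range of 8000 nM to 60000 nM.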

Compound 4, concentration for 50% growth inhibition: 3040 nM
Compound 4: middle estimate off by 8.2-fold (0.92 log units), on the high side; measured number outside the range, below it.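

In this assay, for the compounds shown here, ring size at this place on the ether chain moves the read-out: cyclopentyl in place of cyclohexyl gives an at least 9.8-fold lower number from compound 3 to compound 4 (0.99 log units; beyond the scatter), the first measured step of this kind. Cyclopentyl in place of pentyl gives an at least 9.8-fold lower number from compound 1 to compound 4 (0.99 log units; beyond the scatter), so both a branched chain and a ring can carry measurable activity here, though the cyclohexyl of compound 3 goes against any rule for rings in general. Cyclopentyl and neopentyl cannot be told apart, with a 1.1-fold lower number from compound 2 to compound 4 (0.02 log units; within the scatter).

As far as these compounds go, whether a cyclobutyl ring holds this level remains open. So does the effect of a ring carrying an amine at this place.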